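This account rests on a few compounds, and the source may have more. Where it says the series, first, only, none or still open, it means among the compounds named here.

Compound 1 `COc1ccc(NC(=O)Nc2cc(C)nc3ccccc23)cc1` gives 787 10^-6 cm/s in an ADME assay for permeability, using PAMPA, at pH 7.4; on this read-out higher numbers stand for higher permeability and lower numbers for lower permeability.
Compound 2 `Cc1cc(NC(=O)Nc2ccc(O)cc2)c2ccccc2n1` gives 3 10^-6 cm/s in this assay.
Compound 3 `Cc1cc(NC(=O)Nc2ccc(N(C)C)cc2)c2ccccc2n1` gives 2 10^-6 cm/s in this assay.

Compound 3 stands lowest of the three numbers. Its nearest neighbour is compound 2, which sits a 1.5-fold lower number from compound 2 to compound 3 (0.18 log units; within the scatter) above it, within the scatter. Its furthest neighbour is compound 1, which sits a 390-fold lower number from compound 1 to compound 3 (2.59 log units; beyond the scatter) above it, well beyond the scatter.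

Compound 4 `Cc1cc(NC(=O)Nc2ccc(C(F)(F)F)cc2)c2ccccc2n1` differs from compound 3 in one place: trifluoromethyl in place of dimethylamino on an aromatic carbon. Among the compounds with values here, no measured step shows this exact change. The step that bears most on it is a 390-fold lower number from compound 1 to compound 3 (2.59 log units; beyond the scatter), which was large and downward; the change in compound 4 goes the other way, a trifluoromethyl without hydrogen-bond acceptors entering in place of a dimethylamino. The step of a 260-fold lower number from compound 1 to compound 2 (2.42 log units; beyond the scatter) was likewise large. The step of a 1.5-fold lower number from compound 2 to compound 3 (0.18 log units; within the scatter) was within the scatter and adds little. A large upward step is therefore expected for compound 4 in this assay, of about a 200-fold higher number from compound 3 to compound 4 (2.30 log units; beyond the scatter). The estimate for compound 4 is 400 10^-6 cm/s, with a range from 60 10^-6 cm/s to 1500 10^-6 cm/s.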

Compound 4, apparent permeability: 2 10^-6 cm/s
Compound 4: the middle estimate sits 200-fold (2.30 log units) above what was measured; measured number outside the range, below it.
By their numbers in this assay, from the lowest: compounds 3, 4 and 2 (each within the scatter of the next); then compound 1.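

In this assay trifluoromethyl on this aromatic carbon gives a number level with those of the dimethylamino (no change at the digits printed from compound 3 to compound 4 (within the scatter)) and hydroxy (a 1.5-fold lower number from compound 2 to compound 4 (0.18 log units; within the scatter)) compounds, so a group with 0 hydrogen-bond donors and 0 hydrogen-bond acceptors sits with the other two. Methoxy alone stands apart among the four groups (a 390-fold lower number from compound 1 to compound 4 (2.59 log units; beyond the scatter)), and removing the hydrogen-bond acceptor of dimethylamino does not bring the number near that of compound 1. No measurement offered here accounts for this gap.

On these data alone, it remains open whether the high number belongs to methoxy alone or extends to ethoxy, methyl or a chlorine atom on the same aromatic carbon. As far as these compounds go, whether methoxy gives a similar number on another carbon of this ring also remains open.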